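The compounds below may be only part of what the source reports. "The series", "measured", "known", "first", "only" and "open" are said of these compounds alone.

Working notes on the series. Compound 1, `COc1cccc(OCC(=O)Nc2cccc(NC(=O)c3ccc(N(C)C)cc3)c2)c1`, gives in an assay on isolated protein for inhibition of Rho-associated protein kinase 1 (Homo sapiens), read by scintillation counting, radiometric assay and 33P incorporation, with a stated time of 40 min, in the presence of a further agent that is not named here (a higher number here means a weaker inhibitor, a lower number a stronger inhibitor), only a limit, > 10000 nM, which is the limit of > 10000 nM in this assay, at which 1 of the 3 values shown sits. Compound 2, `CC(=O)c1ccc(OCC(=O)Nc2cccc(NC(=O)c3ccc(N(C)C)cc3)c2)cc1F`, gives 445 nM in this assay; the step of an at least 22-fold lower number from compound 1 to compound 2 (1.35 log units; beyond the scatter) lies at the aryloxy end of the shared core. Compound 3, `Cc1ccc(C(=O)Nc2cccc(NC(=O)COc3ccc4c(=O)ccoc4c3)c2)cc1`, gives 183 nM in this assay, the lowest of the two numbers, with compound 2 as the nearest number, higher by a gap beyond the scatter.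

Compound 4, `O=C(COc1ccc2c(=O)ccoc2c1)Nc1cccc(NC(=O)c2ccc(OC(F)(F)F)cc2)c1`, differs from compound 3 by trifluoromethoxy in place of methyl on an aromatic carbon, para to a large group, on the benzamide end. Going by the values given here, no measured step touches that end; the one step known, an at least 22-fold lower number from compound 1 to compound 2 (1.35 log units; beyond the scatter), concerns the other end, so no change beyond the scatter is expected. Compound 4 is expected near 170 nM, between 55 nM and 550 nM, an expected step of a 1.1-fold lower number from compound 3 to compound 4 (0.03 log units; within the scatter).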

Compound 4, half-maximal inhibitory concentration: 869 nM
Compound 4: the middle estimate sits 5.1-fold (0.71 log units) below what was measured; the measured number lies above the stated range.
By their numbers in this assay, from the lowest: compound 3; then compounds 2 and 4 (each within the scatter of the next). At a limit, above all of these: compound 1.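

In this assay, going by these compounds alone, the benzamide end proves responsive, which the earlier compounds did not show: with trifluoromethoxy in place of methyl, the result is a 4.7-fold higher number from compound 3 to compound 4 (0.68 log units; beyond the scatter). Changes at this position, para to a large group, therefore move the number, as does the change at the aryloxy end. Nothing measured for these compounds bears on the reason for this step.

Open, as far as these compounds go, is how a smaller group such as fluorine, or a carboxylic acid or an amine, would read at this position.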